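The compounds below may be only part of what the source reports. "The series", "measured", "known", "first", "only" and "open" are said of these compounds alone.

Measured compounds:
compound 1: `O=C(O)/C(S)=C/c1c[nH]c2cccc(F)c12` with 300 nM
compound 2: `O=C(O)/C(S)=C/c1c[nH]c2cccc(Cl)c12` with 140 nM
compound 3: `O=C(O)/C(S)=C/c1ccc(Cl)cc1` with 15000 nM

All three were tested in an assay on isolated protein for inhibition of Calpain-1 catalytic subunit (Sus scrofa); on this read-out higher numbers stand for weaker inhibition and lower numbers for stronger inhibition. Compound 2 and compound 1 share one core and differ by fluoro in place of chloro on an aromatic carbon; this change gave a 2.1-fold higher number from compound 2 to compound 1 (0.33 log units; beyond the scatter). Compound 3 is built on a different core, and how the two cores differ is not broken down here. In this assay compound 3 gives 15000 nM, the highest number of the three, far beyond the scatter from both compound 1 and compound 2.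

Compound 4, `O=C(O)/C(S)=C/c1ccc(F)cc1`, has not yet been measured. It differs from compound 3 by fluoro in place of chloro on an aromatic carbon. Among the measured compounds shown here, this is the same kind of change as the one from compound 2 to compound 1, but the surroundings differ: in compound 1 the fluoro sits on a ring that is part of a fused or bridged system of two rings, ortho to a fused ring and meta to a fused ring, whereas in compound 4 it sits on a six-membered aromatic ring of carbon only, para to a group of 6 heavy atoms.

Resting on the single earlier step, a 2.1-fold higher number from compound 2 to compound 1 (0.33 log units; beyond the scatter), compound 4 is expected to show a step of about a 2.0-fold higher number from compound 3 to compound 4 (0.30 log units; within the scatter) in this assay. For the measured compounds named here, the estimate for compound 4 in this assay is therefore 30000 nM, with a likely range from 12000 nM to 80000 nM, since the one precedent rests on a different core and may not transfer in size.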

Compound 4, half-maximal inhibitory concentration: 5600 nM
Compound 4: middle estimate off by 5.4-fold (0.73 log units), on the high side, outside the stated range (below it).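

In this assay, fluoro in place of chloro on an aromatic carbon gave a 2.7-fold lower number from compound 3 to compound 4 (0.43 log units; beyond the scatter), and set beside the earlier step the same change moved the number in opposite directions on the two cores: the same change on two cores in this assay, a 2.1-fold higher number (0.33 log units; beyond the scatter) from compound 2 to compound 1 and a 2.7-fold lower number (0.43 log units; beyond the scatter) from compound 3 to compound 4, 5.7-fold (0.76 log units) apart, beyond the scatter of two such steps. In this series, then, the step seen on the core of compound 1 and compound 2 did not carry over to the core of compound 3 and compound 4, either in direction or in size, so a step measured on one of these cores cannot simply be transferred to the other. Among the compounds shown here, what this does not show is which difference between the cores, or between the surroundings of the halogen on each, reverses the step, and with only two matched pairs it offers no general rule for when fluoro will give the lower number.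

The compounds shown leave open whether a bromo or a methyl group in the same place would also follow a different course on each core, which would show whether the reversal is peculiar to the exchange of chloro and fluoro. They also leave open how either core would respond if an ester or an amide stood in place of the carboxylic acid.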